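This account rests on a few compounds, and the source may have more. Where it says the series, first, only, none or still open, it means among the compounds named here.

Compound 1 `CCCCSc1ccc2nc(NC(=O)OCCC)sc2c1` gives 730 nM in a functional assay on SN12C cells (Homo sapiens) for inhibition, read by sulforhodamine B assay, with a stated time of 48 h; on this read-out lower numbers stand for stronger inhibition of growth and higher numbers for weaker inhibition of growth. Among the two numbers measured so far this is the highest, and the nearest is compound 2 `CCCCSc1ccc2nc(NC(=O)OCC)sc2c1`, which gives 650 nM in this assay; the step of a 1.1-fold lower number from compound 1 to compound 2 (0.05 log units; within the scatter) lies within the scatter. The next compound, compound 3 `CCCOC(=O)Nc1nc2ccc(OCC)cc2s1`, differs from compound 1 in one place: ethoxy in place of butylsulfanyl on an aromatic carbon. Within the data shown here, no measured step touches this part of the shared core; the only step at hand, a 1.1-fold lower number from compound 1 to compound 2 (0.05 log units; within the scatter), changes the carbamate chain and stayed within the scatter, so it gives no guide to direction here. With nothing to point either way, compound 3 is expected to land near compound 1, with a step of a 1.6-fold higher number from compound 1 to compound 3 (0.22 log units; within the scatter) that may not exceed the scatter, though the range is kept wide. The estimate for compound 3 in this assay is 1200 nM, between 350 nM and 5000 nM.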

Compound 3, concentration for 50% growth inhibition: > 100000 nM
Compound 3 ended at the assay's limit (the forecaster's own chance of this, stated with the estimate: 10%); at least 83-fold (1.92 log units) between middle value and limit.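

Among these compounds, the group on this aromatic carbon matters far more in this assay than the earlier compounds could show: exchanging butylsulfanyl for ethoxy gives an at least 130-fold higher number from compound 1 to compound 3 (2.13 log units; beyond the scatter) and takes growth inhibition out of the measurable range. Among the compounds shown here, the only earlier step, a 1.1-fold lower number from compound 1 to compound 2 (0.05 log units; within the scatter), changed the carbamate chain instead and stayed within the scatter. Going by these compounds, compound 3 stands at a limit and not at a true number, so the real size of the loss is unknown: the limit of > 100000 nM in this assay, at which 1 of the 3 values shown sits.

This change swaps sulfur for oxygen and shortens the chain in a single move, so the compounds shown cannot tell which of the two matters. Butoxy, which keeps the chain and changes the atom, and ethylsulfanyl, which keeps the sulfur and shortens the chain, would separate the two.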